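A Sulfonamide in Place of an Amide Side Chain

The source may report more compounds than this note shows. Statements on the series, on what has been measured and on what is new or still open speak of the compounds shown alone.

Compound 1 `O=C(O)CC/C=C\CO[C@H]1[C@@H](OCc2ccc(-c3ccccc3)cc2)CC[C@@H]1N1CCCCC1` was measured in a functional assay on blood for antagonist activity at thromboxane A2 receptor (Homo sapiens) (a higher number here means weaker binding, a lower number tighter binding), where compound 1 gives 10 nM; 7.94 nM (2 entries). Compound 2 `NC(=O)Cc1ccccc1-c1ccc(COC2CC[C@H](N3CCCCCC3)[C@H]2OC/C=C\CCC(=O)O)cc1` in this assay gives 7.94 nM, the only number shown for it there, and the values of compound 1 and compound 2 lie within the usual scatter of each other. Compound 3 `CS(=O)(=O)Nc1ccccc1-c1ccc(COC2CC[C@H](N3CCCCCC3)[C@H]2OC/C=C\CCC(=O)O)cc1` has not yet been measured; it differs from compound 2 by methanesulfonamido in place of carbamoylmethyl on an aromatic carbon. Among the compounds with values here, no measured pair shows this change, so the step expected in this assay is a 1.0-fold higher number from compound 2 to compound 3 (0.00 log units; within the scatter), no change beyond the scatter. Compound 3 is expected to give 8 nM, within a range from 3 nM to 25 nM.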

Compound 3, dissociation constant: 10 nM
Compound 3: the middle estimate sits 1.3-fold (0.10 log units) below what was measured; measured number inside the range.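

Placing methanesulfonamido instead of carbamoylmethyl on this aromatic carbon, ortho to a large group, gives a 1.3-fold higher number from compound 2 to compound 3 (0.10 log units; within the scatter) in this assay. This position therefore accepts two quite different side chains, one built on a sulfur atom and one on a carbonyl, with no difference that can be told from the scatter. Repeated entries of a single compound differ by a similar amount: the several entries of compound 1 in this assay, 10 nM; 7.94 nM (2 entries)

The compounds shown leave open whether a carboxylic acid or a plain amine at this place would give a similar number. They also leave open whether a longer chain carrying the sulfonamide would do the same.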